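This account rests on a few compounds, and the source may have more. Where it says the series, first, only, none or still open, it means among the compounds named here.

Working notes on the series. In a functional assay on HL-60 cells (Homo sapiens) for cytotoxicity, read by CellTiter-Blue, with a stated time of 48 h (on this read-out higher numbers stand for weaker inhibition and lower numbers for stronger inhibition), compound 1 `CCOC(=O)CC1C(C(=O)OCC)=C(N)Oc2ccc(-c3cc(OC)cc(OC)c3)cc21` gives 10700 nM, within the scatter of compound 3 `CCOC(=O)CC1C(C#N)=C(N)Oc2ccc(-c3cc(OC)cc(OC)c3)cc21` at 19600 nM, while compound 2 `C#CCOC(=O)CC1C(C(=O)OCC)=C(N)Oc2ccc(-c3cc(OC)cc(OC)c3)cc21` gives 4700 nM. Compound 1 therefore sits at the upper end of the numbers, alongside compound 3.

The next compound is compound 4 `CCOC(=O)CC1C(C(=O)OCC)=C(N)Oc2ccc(-c3cccc(F)c3)cc21`, which carries 3-fluorophenyl in place of 3,5-dimethoxyphenyl on an aromatic carbon.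

Two measured steps start from compound 1. With ethynyl in place of methyl on the ester chain, the step is a 2.3-fold lower number from compound 1 to compound 2 (0.36 log units; beyond the scatter). With cyano in place of ethoxycarbonyl on a double-bonded ring carbon, the step is a 1.8-fold higher number from compound 1 to compound 3 (0.26 log units; within the scatter). Going by the values given here, neither step touches the aryl group that changes here, and no measured compound varies that group. Among the compounds with values here, they show only that two other changes to the core of compound 1 moved the number little, so they bear on the new step indirectly.

The working expectation in this assay is therefore no shift beyond the scatter, with no firm direction and with wide margins. The expected step is a 1.1-fold higher number from compound 1 to compound 4 (0.05 log units; within the scatter). For compound 4 the estimated value is 12000 nM, with an expected range from 4000 nM to 35000 nM.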

Compound 4, half-maximal inhibitory concentration: 76400 nM
Compound 4: middle estimate off by 6.4-fold (0.80 log units), on the low side; measured number above the stated range.
By their numbers in this assay, from the lowest: compound 2; then compounds 1 and 3 (each within the scatter of the next); then compound 4.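

Within this assay, the aryl group on the aromatic carbon is the first place in the series where a single change has a larger effect than the two changes made elsewhere on the core: a 7.1-fold higher number from compound 1 to compound 4 (0.85 log units; beyond the scatter), against a 2.3-fold lower number from compound 1 to compound 2 (0.36 log units; beyond the scatter) and a 1.8-fold higher number from compound 1 to compound 3 (0.26 log units; within the scatter). The number is therefore sensitive to this aryl group, and of the two groups tested here, 3,5-dimethoxyphenyl goes with the lower number and 3-fluorophenyl with the higher one. The swap removes both methoxy groups and adds a fluorine in one step, taking the count from 10 heavy atoms and 2 hydrogen-bond acceptors to 7 and 0, and no measurement available here explains the shift.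

Going by these compounds alone, the single pair cannot separate the loss of the methoxy groups from the gain of the fluorine, so it remains open whether unsubstituted phenyl, 3-methoxyphenyl or 3,5-difluorophenyl would sit nearer compound 1 or compound 4. On these data alone, it is also open whether the ethynyl change on the ester chain would have the same effect with 3-fluorophenyl in place.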